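A few compounds are considered here, and "the series" means these few. Any claim that something is new, unique, unknown or untested is made for them only; others in the source may bear on it.

Measured compounds:
compound 1 `CCCCCCCCCCCCCC(=O)Nc1nnc(S[C@@H]2O[C@H](CO)[C@H](O)[C@H](O)[C@H]2O)s1` — in a functional assay on HeLa cells (Homo sapiens) for cytotoxicity, read by MTT assay, with a stated time of 24 h (a higher number here means a weaker inhibitor, a lower number a stronger inhibitor), compound 1 gives 31000 nM
compound 2 `CCCCCCCCCCCCCCCC(=O)Nc1nnc(S[C@@H]2O[C@H](CO)[C@H](O)[C@H](O)[C@H]2O)s1` — in this assay compound 2 gives 14200 nM

Compound 2 holds the lower of the two numbers, set apart from compound 1 by a 2.2-fold lower number from compound 1 to compound 2 (0.34 log units; beyond the scatter), a lengthening of the same fatty chain. Compound 3 `CCCCCCCC/C=C\CCCCCCCC(=O)Nc1nnc(S[C@@H]2O[C@H](CO)[C@H](O)[C@H](O)[C@H]2O)s1` is not yet measured; its change from compound 2 is dec-1-en-1-yl in place of octyl on a saturated chain carbon, seven bonds along the chain from a carbonyl carbon. Among the measured compounds shown here, that earlier step is the only one that bears on this change, and the added double bond has no counterpart among the measured compounds. The expected step is a 1.4-fold lower number from compound 2 to compound 3 (0.15 log units; within the scatter), a further modest drop. Compound 3 is expected to give about 10000 nM in this assay, within 4000 nM to 25000 nM.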

Compound 3, half-maximal inhibitory concentration: 8800 nM
For compound 3 the middle estimate is 1.1-fold (0.06 log units) above the measured one; the measured number falls inside the stated range.
By their numbers in this assay, from the lowest: compounds 3 and 2 (each within the scatter of the next); then compound 1.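

In this assay, dec-1-en-1-yl in place of octyl, seven bonds along the chain from a carbonyl carbon, leaves compound 3 within the scatter of compound 2 (a 1.6-fold lower number from compound 2 to compound 3 (0.21 log units; within the scatter)). This position therefore accepts a longer chain with a double bond without a clear shift, yet that chain still stands apart from the hexyl of compound 1 (a 3.5-fold lower number from compound 1 to compound 3 (0.55 log units; beyond the scatter)). No measurement here explains these numbers.

From the compounds shown here alone, compound 3 gains both carbons and a double bond, so the effect of each alone stays unknown. Also open, going by these compounds, is how an amine or a carboxylic acid on this chain would fare.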